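A few compounds are considered here, and "the series" means these few. Any claim that something is new, unique, unknown or untested is made for them only; others in the source may bear on it.

Among the compounds with values here, compound 2 `O=C1O[C@@H](Cn2ccnn2)CN1c1ccc(-n2cc(-c3ccccn3)cn2)c(F)c1` stands at the higher of the two numbers measured so far: in an ADME assay on HEK293-A cells (Homo sapiens) for cytotoxicity, read by MTT assay, with a stated time of 48 h (on this read-out lower numbers stand for stronger inhibition and higher numbers for weaker inhibition), compound 2 gives 225 ug/mL, while compound 1 `CN1CCN(C[C@H]2CN(c3ccc(-n4cc(-c5ccccn5)cn4)c(F)c3)C(=O)O2)CC1` gives 70 ug/mL. Within the data shown here, the only step between measured compounds, a 3.2-fold higher number from compound 1 to compound 2 (0.51 log units; beyond the scatter), changes the same position that is changed here. Compound 3 `O=CNC[C@H]1CN(c2ccc(-n3cc(-c4ccccn4)cn3)c(F)c2)C(=O)O1` carries formylamino in place of 1H-1,2,3-triazol-1-yl on a saturated chain carbon bound to a saturated ring carbon. That step offers only a loose guide, since neither of its groups is the one entering now; a step no larger than modest is expected, if any, with the number for compound 3 estimated to lie close to compound 2, a 1.1-fold lower number from compound 2 to compound 3 (0.05 log units; within the scatter). The estimate for compound 3 is 200 ug/mL, with a range of 90 ug/mL to 400 ug/mL.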

Compound 3, half-maximal inhibitory concentration: > 400 ug/mL
Compound 3: a limit, no number; the forecaster's own chance of this, stated with the estimate: 15%; middle value at least 2.0-fold (0.30 log units) away from the limit.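

In this assay compound 3 gives > 400 ug/mL, which is a limit of the assay and not a number. On a saturated chain carbon bound to a saturated ring carbon, a group without a ring thus stands clear of 4-methylpiperazin-1-yl, with an at least 5.7-fold higher number from compound 1 to compound 3 (0.75 log units; beyond the scatter). Against 1H-1,2,3-triazol-1-yl the reading is only an at least 1.7-fold higher number from compound 2 to compound 3 (0.24 log units; that floor lies within the scatter), so no order between formylamino and that group can be stated.

Going by these compounds, how far compound 3 lies past its limit remains open. Also open, on these data alone, is where an acetylamino group or a primary amine would fall at this place.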